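Swapping a fluorophenyl for a methoxyphenyl on a pyrrolidine

The source may hold more compounds than are shown below. What is called first, only, known or untested is meant among the compounds shown, and "the series" means these compounds.

Of the compounds shown here, two have been measured in an in vitro assay on Sf9 cells for inhibition of Rho-associated protein kinase 2 (Homo sapiens), read by TR-FRET, with a stated time of 25 min; a higher number here means a weaker inhibitor, a lower number a stronger inhibitor. Compound 1, with the structure `C[N+]1(C)C[C@@H](c2ccccc2)[C@H](c2nc3ccc(-c4cn[nH]c4)cc3c(=O)[nH]2)C1`, gives 4 nM in this assay. Compound 2, with the structure `O=c1[nH]c([C@@H]2CN(Cc3ccccc3)C[C@H]2c2ccccc2F)nc2ccc(-c3cn[nH]c3)cc12`, gives 49 nM in this assay. Among the two, compound 2 therefore stands at the higher number, the weaker inhibitor, and its gap to compound 1 lies beyond the usual scatter of repeated measurements.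

The next compound, compound 3, has the structure `COc1ccc([C@@H]2CN(Cc3ccccc3)C[C@H]2c2nc3ccc(-c4cn[nH]c4)cc3c(=O)[nH]2)cc1`. Compared with compound 2 the change is 4-methoxyphenyl in place of 2-fluorophenyl on a saturated ring carbon. Everything else in the molecule, including the benzyl group on the ring nitrogen and the shared core, stays the same.

Nothing has been measured on this particular exchange, so the direction is open. The two measured compounds differ in several places at once and do not isolate this part of the molecule. The step from compound 2 to compound 3 is therefore expected to be small, a 1.0-fold higher number from compound 2 to compound 3 (0.01 log units; within the scatter), not clearly beyond the scatter in either direction. Compound 3 is estimated at 50 nM in this assay, within a range from 15 nM to 170 nM.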

Compound 3, half-maximal inhibitory concentration: 88 nM
Beside the measured number, compound 3's estimate is 1.8-fold (0.25 log units) below it; the measured number falls inside the stated range.
By their numbers in this assay, from the lowest: compound 1; then compounds 2 and 3 (each within the scatter of the next).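

In this assay this exchange on a saturated ring carbon of the five-membered ring gives a 1.8-fold higher number from compound 2 to compound 3 (0.25 log units; within the scatter) and so leaves compound 2 and compound 3 indistinguishable. Among these compounds, this is the first direct reading at this position. The two earlier compounds differed in several places at once. The aromatic ring stays in both compounds, while its substituent and that substituent's place both change and the entering group adds a hydrogen-bond acceptor; with the benzyl group on the ring nitrogen in place, this combined change has no effect that can be told from the scatter. Nothing measured here offers an explanation for this result.

A 4-fluorophenyl or a 2-methoxyphenyl would be needed to separate the choice of substituent from its place on the aromatic ring, and a phenyl ring carrying an amine or a carboxylic acid would test a much larger change at this ring carbon. Going by these compounds, whether the exchange reads the same way with something other than the benzyl group on the ring nitrogen also remains open.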